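The source may hold more compounds than are shown below. What is called first, only, known or untested is meant among the compounds shown, and "the series" means these compounds.

Compound 1 `COc1ccc(/C=C\c2cc(OC)c(OC)c(OC)c2)cc1OCc1ccc(C=O)cc1` in a functional assay on HepG2 cells (Homo sapiens) for antiproliferative activity, read by CCK-8 assay, with a stated time of 48 h (a lower number here means a stronger inhibitor, a higher number a weaker inhibitor), gives 800 nM. Compound 2 `COc1ccc(/C=C\c2cc(OC)c(OC)c(OC)c2)cc1OCc1ccc(CN2CCCCC2C(=O)O)cc1` gives 3100 nM, and compound 3 `COc1ccc(/C=C\c2cc(OC)c(OC)c(OC)c2)cc1OCc1ccc(CN2CC[C@H](C(=O)O)C2)cc1` gives 6400 nM. Among these three numbers compound 2 holds the second highest: its nearest neighbour is reached by a 2.1-fold higher number from compound 2 to compound 3 (0.31 log units; beyond the scatter), and its furthest by a 3.9-fold higher number from compound 1 to compound 2 (0.59 log units; beyond the scatter). Compound 4 `COc1ccc(/C=C\c2cc(OC)c(OC)c(OC)c2)cc1OCc1ccc(CN2CC[C@@H](C(=O)O)C2)cc1` has not yet been measured in this assay. It differs from compound 2 by 3-carboxypyrrolidin-1-yl in place of 2-carboxypiperidin-1-yl on a saturated chain carbon bound to an aromatic carbon. Among the measured compounds shown here, only one measured step bears on this change: the step of a 2.1-fold higher number from compound 2 to compound 3 (0.31 log units; beyond the scatter) carries the same group into the same place, with the stereocentre set the other way, and lands just beyond the scatter. On that basis compound 4 is expected to show a modest rise in the number, a 1.9-fold higher number from compound 2 to compound 4 (0.29 log units; within the scatter). The estimate for compound 4 in this assay is 6000 nM, within a range from 3000 nM to 12000 nM; a single bearing step makes this expectation a loose one.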

Compound 4, half-maximal inhibitory concentration: 2300 nM
Estimate against measurement, compound 4: 2.6-fold (0.42 log units) above, outside the stated range (below it).
By their numbers in this assay, from the lowest: compound 1; then compounds 4 and 2 (each within the scatter of the next); then compound 3.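

In this assay the configuration of the 3-carboxypyrrolidin-1-yl group carries weight, and a 2.8-fold lower number from compound 3 to compound 4 (0.44 log units; beyond the scatter) can be assigned to the ring stereocentre alone, drawn R rather than S, because of what this pair shares: the fact that compounds 3 and 4 differ only in the configuration as drawn. With the R form, the exchange for 2-carboxypiperidin-1-yl gives a 1.3-fold lower number from compound 2 to compound 4 (0.13 log units; within the scatter), so the rise seen earlier with the S form does not hold for this ring exchange as a whole. Against the formyl group, the R form still gives a 2.9-fold higher number from compound 1 to compound 4 (0.46 log units; beyond the scatter), leaving compound 1 with the lowest number of the four.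

Whether the carboxylic acid itself accounts for that gap stays open, as the compounds shown include no plain piperidin-1-ylmethyl or pyrrolidin-1-ylmethyl group. On these data alone, the 2-carboxypiperidin-1-yl group of compound 2 has no defined stereocentre, so how its separate configurations compare also remains unknown.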